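The compounds below may be only part of what the source reports. "The series", "measured", "known", "first", "only" and "open" are said of these compounds alone.

Three compounds share one core and differ only in the group attached to the saturated chain carbon bound to a carbonyl carbon and a saturated chain carbon. Compound 1 `CCCCCCCCCCCCCCNC(=O)[C@H](CO)/N=C/c1cccc(Cl)c1` gives 24100 nM in a functional assay on cells (Homo sapiens) for cytotoxicity, read by MTT assay, with a stated time of 24 h (on this read-out higher numbers stand for weaker inhibition and lower numbers for stronger inhibition), which is the lowest of the three numbers and therefore the strongest inhibition seen so far. Compound 2 `CCCCCCCCCCCCCCNC(=O)[C@H](CO)NCc1ccccc1OC` gives 100000 nM, and compound 3 `CCCCCCCCCCCCCCNC(=O)[C@H](CO)/N=C/c1cccc([N+](=O)[O-])c1` gives 104000 nM. Both changes away from compound 1 led to higher numbers: a 4.1-fold higher number from compound 1 to compound 2 (0.62 log units; beyond the scatter) and a 4.3-fold higher number from compound 1 to compound 3 (0.64 log units; beyond the scatter).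

Compound 4 `CCCCCCCCCCCCCCNC(=O)[C@H](CO)/N=C/c1ccccc1` has not yet been measured. It differs from compound 1 in one place: hydrogen in place of chloro on an aromatic carbon. The same difference, cut one bond further out, reads 3-chlorophenyl to phenyl. Among the compounds with values here, no measured step removes the chloro outright. The closest comparisons are the step from compound 1 to compound 3, where nitro in place of chloro gave a higher number, and the step from compound 1 to compound 2, where the whole group changed and the number also rose. Taking these two modest rises as a guide, compound 4 is expected to lie at a higher number, with an expected step of a 2.3-fold higher number from compound 1 to compound 4 (0.36 log units; beyond the scatter). The estimate for compound 4 in this assay is 55000 nM, with a range from 20000 nM to 130000 nM.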

Compound 4, half-maximal inhibitory concentration: 7670 nM
Compound 4: the middle estimate sits 7.2-fold (0.86 log units) above what was measured; measured number below the stated range.
By their numbers in this assay, from the lowest: compound 4; then compound 1; then compounds 2 and 3 (each within the scatter of the next).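

In this assay the chloro turns out not to be needed on this aromatic carbon: hydrogen in place of chloro gives a 3.1-fold lower number from compound 1 to compound 4 (0.50 log units; beyond the scatter) and so stronger inhibition, not weaker. Compound 1 had stood lowest only against nitro and the methoxy-bearing compound, whereas hydrogen in place of nitro gives a 14-fold lower number from compound 3 to compound 4 (1.13 log units; beyond the scatter) and shows that, among compounds 1, 3 and 4, the ring with no group at this place has the lowest number, with both chloro and nitro higher. The wider change gives a 13-fold lower number from compound 2 to compound 4 (1.12 log units; beyond the scatter) as well, but there the link to the ring and the group on the ring differ together, so that large step cannot be assigned to either one alone.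

Nothing measured here explains why the numbers move this way. Still open, going by these compounds, is whether a fluoro, a methyl or an amine on this same aromatic carbon would also raise the number, and how a shorter chain in place of the long saturated one would alter inhibition in the unsubstituted compound.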